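Furan-3-yl in place of thiophen-2-yl on a carbonyl carbon

The source may report more compounds than this note shows. Statements on the series, on what has been measured and on what is new or still open speak of the compounds shown alone.

Within the data shown here, in a functional assay on HBC4 cells (Homo sapiens) for inhibition, read by colorimetric assay and sulforhodamine B assay, with a stated time of 48 h (on this read-out higher numbers stand for weaker inhibition of growth and lower numbers for stronger inhibition of growth), compound 1 (`CCCCCCCCCCCC[C@@H](O)[C@H]1CC[C@H]([C@H](O)CCCCCCCCCCNC(=O)c2cccs2)O1`) gives 3390 nM, the lower of the two numbers known so far. Among the measured compounds shown here, compound 2 (`CCCCCCCCCCCC[C@@H](O)[C@H]1CC[C@H]([C@H](O)CCCCCCCCCCNC(=O)c2ccco2)O1`), its furan-2-yl counterpart, gives 100000 nM, and this large change is the only measured step available: a 29-fold higher number from compound 1 to compound 2 (1.47 log units; beyond the scatter). Compound 3 (`CCCCCCCCCCCC[C@@H](O)[C@H]1CC[C@H]([C@H](O)CCCCCCCCCCNC(=O)c2ccoc2)O1`) instead carries furan-3-yl in place of thiophen-2-yl on a carbonyl carbon. Furan-3-yl is not the group in compound 2, so that step guides only loosely, but a sizeable rise in this assay is expected, probably a smaller one. The expected step is a 5.9-fold higher number from compound 1 to compound 3 (0.77 log units; beyond the scatter). Compound 3 is estimated at 20000 nM, with an expected range from 5000 nM to 100000 nM.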

Compound 3, concentration for 50% growth inhibition: 100000 nM
For compound 3 the middle estimate is 5.0-fold (0.70 log units) below the measured one, within the range that was stated.
By their numbers in this assay, from the lowest: compound 1; then compounds 2 and 3 (each within the scatter of the next).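

In this assay, furan-3-yl on this carbonyl carbon costs as much as furan-2-yl did (a 29-fold higher number from compound 1 to compound 3 (1.47 log units; beyond the scatter)), so the loss seen earlier is not confined to a single furan attachment. Exchanging one furan for the other shows no difference (no change at the digits printed from compound 2 to compound 3 (within the scatter)), and among these three compounds only compound 1, with thiophen-2-yl, stands apart. Nothing available here accounts for the gap between the thiophene and the furans. Still open, as far as these compounds go, is how thiophen-3-yl or a phenyl ring would behave on this carbonyl carbon, and so whether thiophen-2-yl is unusual here or the two furans are.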